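The source may report more compounds than this note shows. Statements on the series, on what has been measured and on what is new or still open speak of the compounds shown alone.

On a functional assay on A549 cells (Homo sapiens) for cytotoxicity, read by MTT assay, with a stated time of 72 h (on this read-out lower numbers stand for stronger inhibition and higher numbers for weaker inhibition), compound 3 (`O=C1c2c[n+]([O-])c3ccccc3c2C(=O)c2c1c1ccccc1n2CCCCN1CCCCC1`) gives 150 nM and is the strongest of the three measured compounds. Compound 1 (`CCCCN1CCN(CCCCn2c3c(c4ccccc42)C(=O)c2c[n+]([O-])c4ccccc4c2C3=O)CC1`) gives 550 nM on the same read-out, and compound 2 (`CC1(C)OC[C@@H](Cn2cc(Cn3c4c(c5ccccc53)C(=O)c3c[n+]([O-])c5ccccc5c3C4=O)nn2)O1`) gives 4700 nM there.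

Compound 4 (`CN1CCN(CCCCCn2c3c(c4ccccc42)C(=O)c2c[n+]([O-])c4ccccc4c2C3=O)CC1`) has not yet been measured. Its difference from compound 3 is (4-methylpiperazin-1-yl)methyl in place of piperidin-1-yl on a saturated chain carbon, four bonds along the chain from an aromatic nitrogen and it lies on a saturated chain carbon, four bonds along the chain from an aromatic nitrogen. Read one bond further out, 3-(piperidin-1-yl)propyl becomes 4-(4-methylpiperazin-1-yl)butyl.

Among the compounds with values here, the one measured step that bears on this is a 3.7-fold lower number from compound 1 to compound 3 (0.56 log units; beyond the scatter) and it is modest but beyond the scatter, with piperidin-1-yl replacing 4-butylpiperazin-1-yl at that same place. Within the data shown here, with compound 1 at 550 nM as the only measured piperazin-1-yl example, compound 4 is expected to give back part of that step. Among the measured compounds shown here, no measured step separates the ring group from the chain change.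

The expected size is a 2.3-fold higher number from compound 3 to compound 4 (0.37 log units; beyond the scatter) on this assay as a modest move toward weaker inhibition. For compound 4 the estimate is 350 nM with an expected range of 120 nM to 1000 nM as the likely span.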

Compound 4, half-maximal inhibitory concentration: 870 nM
Compound 4: middle estimate off by 2.5-fold (0.40 log units), on the low side; low and high end bracket the measured number.
By their numbers in this assay, from the lowest: compound 3; then compounds 1 and 4 (each within the scatter of the next); then compound 2.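

In this assay, replacing piperidin-1-yl with (4-methylpiperazin-1-yl)methyl gives a larger step than the one seen before (a 5.8-fold higher number from compound 3 to compound 4 (0.76 log units; beyond the scatter)), so compound 3 now stands apart from two piperazine compounds instead of one. Exchanging 4-butylpiperazin-1-yl for (4-methylpiperazin-1-yl)methyl gives a step within the usual scatter (a 1.6-fold higher number from compound 1 to compound 4 (0.20 log units; within the scatter)), so these two compounds cannot be told apart at this place. No measurement shown here explains either step.

The compounds shown leave open how much of the step to compound 4 belongs to the ring and how much to the longer chain, as 3-(piperidin-1-yl)propyl becomes 4-(4-methylpiperazin-1-yl)butyl. Also open, as far as these compounds go, is how a morpholine ring or an open-chain amine such as dimethylamino would compare at this place.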